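Changing the sulfonyl aryl group of compound 2

A few compounds are considered here, and "the series" means these few. Any claim that something is new, unique, unknown or untested is made for them only; others in the source may bear on it.

compound 1 `O=C1NCc2ncc(-c3ccc(-c4cncc(NS(=O)(=O)c5ccc(F)cc5F)c4)s3)cc21`: 83%
compound 2 `CN1Cc2cc(-c3ccc(-c4cncc(NS(=O)(=O)c5ccc(F)cc5F)c4)s3)cnc2C1=O`: 100%

Of the two measured compounds, compound 2 stands highest in an ADME assay on microsomes from liver (Mus musculus, strain CD1) for metabolic stability, read by LC-MS, using NADPH, with a stated time of 30 min, tested at 3 uM (a higher number here means that more of the compound is left, a lower number that less of the compound is left), at 100%. Compound 3 `CN1Cc2cc(-c3ccc(-c4cncc(NS(=O)(=O)c5cccc(C(F)(F)F)c5)c4)s3)cnc2C1=O` differs from it by one change: 3-(trifluoromethyl)phenyl in place of 2,4-difluorophenyl on a sulfonyl sulfur, with 3-(trifluoromethyl)phenyl in place of 2,4-difluorophenyl on a sulfonyl sulfur. For the measured compounds named here, the only measured step, a number 17 percentage points higher from compound 1 to compound 2 (beyond the scatter), was modest and concerns a different group, so it offers no direct guide to this change. With compound 2 at 100%, little room remains upward, so a small fall is expected. The estimated change is a number 10 percentage points lower from compound 2 to compound 3 (within the scatter). Compound 3 is expected at 90%, with an estimated range of 72% to 100%.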

Compound 3, percent of the compound remaining: 88%
The estimate for compound 3 lay 2 percentage points above the measured number; the measured number falls inside the stated range.
By their numbers in this assay, from the lowest: compounds 1 and 3 (each within the scatter of the next); then compound 2.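

Replacing the group on the sulfonyl sulfur has a measurable effect in this assay: 3-(trifluoromethyl)phenyl in place of 2,4-difluorophenyl gives a number 12 percentage points lower from compound 2 to compound 3 (beyond the scatter). For the compounds shown here, the earlier pair differed elsewhere, so this is the first sign that this position also affects the amount of compound left. Nothing available explains the fall.

From the compounds shown here alone, whether the fall comes from adding the trifluoromethyl group or from losing the two fluorines stays open, as both happen in one step. Going by these compounds, how an unsubstituted phenyl or a pyridyl group would behave on the sulfonyl sulfur also remains unknown.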